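Adding a Second Methoxy Group: Cytotoxicity on Vero Cells

This account rests on a few compounds, and the source may have more. Where it says the series, first, only, none or still open, it means among the compounds named here.

Four compounds share a core that is kept unchanged throughout. Compound 1 `CC1(c2ccc(NC(c3ccncc3)c3nnnn3C(C)(C)C)cc2)NC(=O)c2ccccc2N1` stands in an ADME assay on Vero cells (Chlorocebus sabaeus) for cytotoxicity, read by MTT assay, with a stated time of 72 h (a higher number here means that more compound is tolerated, a lower number that less compound is tolerated), as "not determined" (no result reported), so no result was reported for it. Compound 2 `COc1ccc(-c2cc(-c3ccc(C4NC(=O)c5ccccc5N4)cc3)nc(N)n2)cc1` gives 124000 nM in this assay. Compound 3 `CC1(c2ccc(Nc3nc(NCc4ccccc4)nc(NCc4ccccc4)n3)cc2)NC(=O)c2ccccc2N1` gives 359000 nM in this assay. Of the two numbers available, compound 2 therefore stands as the lower one, meaning less of it is tolerated by the cells than of compound 3, and the gap between the two lies beyond the usual scatter of repeated measurements. Compound 1 contributes no number to this comparison.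

Compound 4 `COc1cccc(-c2cc(-c3ccc(C4NC(=O)c5ccccc5N4)cc3)nc(N)n2)c1OC` has not been measured yet. It differs from compound 2 in one place: 2,3-dimethoxyphenyl in place of 4-methoxyphenyl on an aromatic carbon. Going by the values given here, no pair of measured compounds differing in a single place is available, so no measured step can guide the expectation. The change is modest in size and adds one methoxy group on an aromatic carbon, and the expected step from compound 2 to compound 4 in this assay is a 1.1-fold lower number from compound 2 to compound 4 (0.05 log units; within the scatter), that is, none beyond the scatter. For compound 4 in this assay the estimate is 110000 nM, with a range from 45000 nM to 270000 nM.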

Compound 4, half-maximal cytotoxic concentration: > 400000 nM
Compound 4 was reported as a limit; the forecaster's own chance of this, stated with the estimate: 10%; middle value at least 3.6-fold (0.56 log units) away from the limit.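

Compound 4 gives > 400000 nM in this assay, which is a limit of the assay and not a number. Going by these compounds alone, replacing 4-methoxyphenyl with 2,3-dimethoxyphenyl, on the aromatic carbon next to the ring nitrogen, produces an at least 3.2-fold higher number from compound 2 to compound 4 (0.50 log units; beyond the scatter), the first step in this set that changes only one place, and it shows that the group at this position can shift how much compound the cells tolerate. For compound 4 only a lower bound on the size of the step can be stated, because its reading ends at a limit: the limit of > 400000 nM in this assay, at which 1 of the 4 values shown sits.

This single step changes two things together, the arrival of a second methoxy group and the places of the methoxy groups on the phenyl ring, and the compounds shown do not separate the two. As far as these compounds go, how a plain phenyl ring, or a phenyl ring carrying an amine or a carboxylic acid instead of methoxy, would read at this position also remains open.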